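Shifting the Hydroxyl Around One Aryl Ring

This account rests on a few compounds, and the source may have more. Where it says the series, first, only, none or still open, it means among the compounds named here.

For the measured compounds named here, compound 2 `Oc1ccc(-c2cc(-c3cccs3)cc(-c3cccc(O)c3)n2)cc1` holds the only number in a functional assay on HCT-15 cells (Homo sapiens) for cytotoxicity, read by CCK-8 assay (on this read-out higher numbers stand for weaker inhibition and lower numbers for stronger inhibition), where compound 2 gives 1770 nM. Compound 1 `Oc1ccc(-c2cc(-c3cccs3)cc(-c3ccccc3O)n2)cc1` reaches only a limit there, > 50000 nM (the limit of > 50000 nM in this assay, at which 1 of the 2 values shown sits). The step of an at least 28-fold lower number from compound 1 to compound 2 (1.45 log units; beyond the scatter) shows how strongly the placement of this hydroxyl can matter. Compound 3 `Oc1ccc(-c2cc(-c3cccs3)cc(-c3ccc(O)cc3)n2)cc1` differs from compound 2 by 4-hydroxyphenyl in place of 3-hydroxyphenyl on an aromatic carbon, a further shift of the same hydroxyl. Going by the values given here, only that one measured step bears on the change, and it gives no direction for a second shift, so a step near the scatter is expected. Compound 3 is therefore expected to give 2500 nM, between 600 nM and 12000 nM, a step of a 1.4-fold higher number from compound 2 to compound 3 (0.15 log units; within the scatter).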

Compound 3, half-maximal inhibitory concentration: > 50000 nM
Compound 3 gave a limit, no number; the forecaster's own chance of this, stated with the estimate: 10%; middle value at least 20-fold (1.30 log units) from the limit.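

The further shift of the hydroxyl gives an at least 28-fold higher number from compound 2 to compound 3 (1.45 log units; beyond the scatter) in this assay, so the 3-hydroxyphenyl group of compound 2 now stands apart from both other placements on this ring, not from one alone. Compound 1 and compound 3 both stand at a limit and not at a number, so the step between them cannot be read: the limit of > 50000 nM in this assay, at which 2 of the 3 values shown sit.

The compounds shown leave open whether the hydroxyl itself is needed on this ring. An amine or a carboxylic acid in its place on the 3-hydroxyphenyl group of compound 2 could keep or lose that number.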